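The source may hold more compounds than are shown below. What is called first, only, known or untested is meant among the compounds shown, and "the series" means these compounds.

Measured in a functional assay on PC-3 cells (Homo sapiens) for cytotoxicity, read by MTT assay, with a stated time of 48 h; on this read-out lower numbers stand for stronger inhibition and higher numbers for weaker inhibition:
- compound 1 `COc1cccc(/C=C/[C@](C)(O)CC[C@@H]2[C@@]3(C)CCCC(C)(C)[C@@H]3CC[C@@]2(C)O)c1OC`: 2900 nM
- compound 2 `CC1(C)CCC[C@]2(C)[C@@H](CC[C@@](C)(O)/C=C/c3ccc(Br)cc3)[C@](C)(O)CC[C@@H]12`: 41300 nM
- compound 3 `CC1(C)CCC[C@]2(C)[C@@H](CC[C@@](C)(O)/C=C/c3ccc(F)cc3)[C@](C)(O)CC[C@@H]12`: 82 nM

Compound 3 has the lowest number of the three, and its steps to both of the others lie beyond the scatter. Compound 4 `CC1(C)CCC[C@]2(C)[C@@H](CC[C@@](C)(O)/C=C/c3ccc(Oc4ccccc4)cc3)[C@](C)(O)CC[C@@H]12` departs from it in one place: phenoxy in place of fluoro on an aromatic carbon. The closest measured evidence is the exchange of bromo for fluoro on that same carbon, a 500-fold lower number from compound 2 to compound 3 (2.70 log units; beyond the scatter), which is large. The swap of the whole aryl group also counts, a 35-fold lower number from compound 1 to compound 3 (1.55 log units; beyond the scatter), and is large too. Each measured departure from compound 3 therefore gives a much higher number, though only two such departures exist and neither involves phenoxy. A large rise is therefore expected in this assay, probably short of the full bromo gap. The expected change is a 37-fold higher number from compound 3 to compound 4 (1.56 log units; beyond the scatter). For compound 4 the estimated value is 3000 nM, with an expected range from 300 nM to 30000 nM.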

Compound 4, half-maximal inhibitory concentration: 268 nM
Compound 4: middle estimate off by 11-fold (1.05 log units), on the high side; the measured number lies below the stated range.
By their numbers in this assay, from the lowest: compound 3; then compound 4; then compound 1; then compound 2.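

At the aromatic carbon of compound 3, this assay shows that fluoro can give way to a far bigger group at a modest cost: phenoxy, with 7 heavy atoms against 1, brings only a 3.3-fold higher number from compound 3 to compound 4 (0.51 log units; beyond the scatter). The same phenoxy group still gives a 150-fold lower number from compound 2 to compound 4 (2.19 log units; beyond the scatter), so on this ring the number does not simply climb as the group at this carbon grows, and bromo, not the largest of the three, gives the highest number. Nothing measured here explains this order.

The compounds shown leave open whether the oxygen link or the second ring matters more, which a directly attached phenyl or a benzyl group at this carbon could separate. They also leave open where chloro, an amine or a carboxylic acid would fall relative to fluoro and bromo.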